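This account rests on a few compounds, and the source may have more. Where it says the series, first, only, none or still open, it means among the compounds named here.

Working notes on the series. Compound 1 `NS(=O)(=O)NCC1CCN(c2cc(-c3ccccc3)ncn2)CC1` carries the shared core with an unsubstituted phenyl ring. In a functional assay on HT-29 cells (Homo sapiens) for antiproliferative activity, read by sulforhodamine B assay, with a stated time of 48 h (a higher number here means a weaker inhibitor of growth, a lower number a stronger inhibitor of growth), compound 1 gives > 100000 nM, which is a limit of the assay and not a number. Compound 2 `NS(=O)(=O)NCC1CCN(c2cc(-c3ccccc3Cl)ncn2)CC1` differs by a chloro in place of hydrogen on an aromatic carbon. In this assay compound 2 gives > 100000 nM, again a limit of the assay. Compound 3 `NS(=O)(=O)NCCC1CCN(c2cc(-c3ccccc3)ncn2)CC1` lengthens the chain, (sulfamoylamino)methyl in place of sulfamoylamino on a saturated chain carbon bound to a saturated ring carbon. In this assay, for the measured compounds named here, compound 3 gives 66500 nM, the only number among the three results; the other two sit at the limit of > 100000 nM in this assay, at which 2 of the 3 values shown sit. The step of an at least 1.5-fold lower number from compound 1 to compound 3 (0.17 log units; that floor lies within the scatter) is therefore read against a limit, and the step that the two limits leave unreadable from compound 1 to compound 2 cannot be read at all.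

Compound 4 `CC(C)(C)c1ccc(-c2cc(N3CCC(CCNS(N)(=O)=O)CC3)ncn2)cc1` is the next member: tert-butyl in place of hydrogen on an aromatic carbon. No measured step touches this position with a group of this kind; the chloro step from compound 1 to compound 2 is the only aryl change shown and it is unreadable between two limits. The expectation for compound 4 is therefore set close to compound 3, with a wide range.

Compound 4 is expected to give about 30000 nM in this assay, between 8000 nM and 100000 nM.

The expected step from compound 3 to compound 4 is a 2.2-fold lower number from compound 3 to compound 4 (0.35 log units; beyond the scatter).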

Compound 4, concentration for 50% growth inhibition: 10300 nM
Beside the measured number, compound 4's estimate is 2.9-fold (0.46 log units) above it; the measured number falls inside the stated range.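

In this assay, tert-butyl in place of hydrogen on an aromatic carbon, para to a large group, gives the first readable step from a change on this aromatic ring: a 6.5-fold lower number from compound 3 to compound 4 (0.81 log units; beyond the scatter). This shows that a substituent on this ring can move the number beyond the scatter, although the series offers this one group at this one place, on the longer chain of compound 3. The chloro step from compound 1 to compound 2 still cannot be read, as each of these compounds gives a limit of the assay and not a number: the limit of > 100000 nM in this assay, at which 2 of the 4 values shown sit.

From the compounds shown here alone, whether methyl, methoxy, an amine or a carboxylic acid at the same place would shift the number in the same direction, or by a similar size, stays open. Also open, going by these compounds, is whether tert-butyl would give a readable number on the shorter chain of compound 1.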